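Removing the thiophen-2-yl group from compound 2

A few compounds are considered here, and "the series" means these few. Any claim that something is new, unique, unknown or untested is made for them only; others in the source may bear on it.

Compound 2 `N=C(S)CCn1nc(-c2cccs2)ccc1=O` was tested in a functional assay on the whole organism (stomach) with Rattus norvegicus as the target (on this read-out higher numbers stand for an effect only at larger amounts of compound and lower numbers for an effect already at smaller amounts), and gave 100 mg/kg. Compound 3 `N=C(S)CCn1ncccc1=S` gave 100 mg/kg in this assay, a value level with that of compound 2 within the scatter. For compound 1 `CC(Cn1ncccc1=O)C(=N)S` the result in this assay is a limit of the assay, > 100 mg/kg. The change from compound 2 to compound 4 `N=C(S)CCn1ncccc1=O` is hydrogen in place of thiophen-2-yl on an aromatic carbon. Going by the values given here, no step between measured compounds is at hand, and the two numbers that are known stand level, so the expected step is none beyond the scatter, no change at the digits printed from compound 2 to compound 4 (within the scatter). Compound 4 is therefore estimated to give about 100 mg/kg in this assay, within a range from 50 mg/kg to 200 mg/kg.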

Compound 4, dose for half-maximal effect: > 100 mg/kg
Compound 4 gave a limit, no number; the forecaster's own chance of this, stated with the estimate: 40%; the middle value lies on the limit itself.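

With hydrogen in place of thiophen-2-yl on this aromatic carbon, this assay shows a number no lower from compound 2 to compound 4 (the limit leaves the size open). Compound 4 gives > 100 mg/kg, which is a limit of the assay. This is the first step at this position, and it can be read only in its direction, while the step between compound 1 and compound 4 cannot be read at all, and the read-out is crowded at its end: the limit of > 100 mg/kg in this assay, at which 2 of the 4 values shown sit.

As far as these compounds go, how large the step from the thiophen-2-yl compound is remains open. So does what an amine or a phenyl group on this carbon would give.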